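The compounds below may be only part of what the source reports. "The series", "measured", "known", "first", "only" and "open" are said of these compounds alone.

Measured so far:
- compound 1 `CC1=NC(C)=C([N+](=O)[O-])C(c2cccc(C)n2)/C1=C(/O)OCCc1ccccc1`: 9980 nM
- compound 2 `CC1=NC(C)=C([N+](=O)[O-])C(c2ncccc2C(F)(F)F)/C1=C(/O)OCCc1ccccc1`: > 59800 nM
- compound 3 `CC1=NC(C)=C([N+](=O)[O-])C(c2cccc(Cl)n2)/C1=C(/O)OCCc1ccccc1`: 1510 nM

In a functional assay (muscle tissue) with Cavia porcellus as the target (on this read-out higher numbers stand for weaker inhibition and lower numbers for stronger inhibition), compound 3 holds the lowest of the two numbers given; its nearest neighbour is compound 1, with a 6.6-fold lower number from compound 1 to compound 3 (0.82 log units; beyond the scatter). For compound 2 the value is a limit of this assay, not a number (the limit of > 59800 nM in this assay, at which 1 of the 3 values shown sits).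

Compound 4 `CC1=NC(C)=C([N+](=O)[O-])C(c2ncccc2Cl)/C1=C(/O)OCCc1ccccc1` differs from compound 3 in one place: 3-chloropyridin-2-yl in place of 6-chloropyridin-2-yl on a saturated ring carbon. Among the measured compounds shown here, two measured steps bear on this change. an at least 5.9-fold higher number from compound 1 to compound 2 (0.77 log units; beyond the scatter) and an at least 39-fold lower number from compound 2 to compound 3 (1.59 log units; beyond the scatter) both involve the shift from a group on the pyridine position named 6 to one named 3, and both point the same way: the number rises. A rise beyond the scatter is therefore expected for compound 4, though chloro is a different group from trifluoromethyl. Compound 4 is expected at 15000 nM, within 3000 nM to 80000 nM. The expected step is a 9.9-fold higher number from compound 3 to compound 4 (1.00 log units; beyond the scatter).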

Compound 4, half-maximal inhibitory concentration: 5170 nM
The estimate for compound 4 lay 2.9-fold (0.46 log units) above the measured number; low and high end bracket the measured number.
By their numbers in this assay, from the lowest: compound 3; then compounds 4 and 1 (each within the scatter of the next). At a limit, above all of these: compound 2.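

In this assay, moving the chloro group alone, with the same atoms joined differently, gives a 3.4-fold higher number from compound 3 to compound 4 (0.53 log units; beyond the scatter), so 3-chloropyridin-2-yl and 6-chloropyridin-2-yl are not interchangeable on this saturated ring carbon. Chloro in place of trifluoromethyl on the aromatic carbon gives an at least 11-fold lower number from compound 2 to compound 4 (1.06 log units; beyond the scatter), while a 1.9-fold lower number from compound 1 to compound 4 (0.29 log units; within the scatter) leaves 3-chloropyridin-2-yl and 6-methylpyridin-2-yl indistinguishable in this read-out. For compound 2 the value is a limit, not a number: the limit of > 59800 nM in this assay, at which 1 of the 4 values shown sits.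

The compounds shown leave open how an amine or a methoxy group would compare with chloro on the pyridine.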